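Notes on oxanyl replacement at the pyrazole carbon

A few compounds are considered here, and "the series" means these few. Any claim that something is new, unique, unknown or untested is made for them only; others in the source may bear on it.

Compound 1 `COc1ccccc1-n1nc([C@H]2C[C@@H](C)O[C@@H](C)C2)cc1-c1ccc(Cl)cc1` gives 64% in an ADME assay on microsomes from liver (Homo sapiens) for metabolic stability, with a stated time of 10 min (on this read-out higher numbers stand for a more stable compound and lower numbers for a less stable compound), the second highest of the three numbers: compound 2 `COc1ccccc1-n1nc(C2CCOC(C)(C)C2)cc1-c1ccc(Cl)cc1` gives 98% and compound 3 `COc1ccccc1-n1nc(C2C[C@H](C)O[C@@H](C)C2)cc1-c1ccc(Cl)cc1` gives 40%. For the measured compounds named here, the two largest steps both concern the same ring, a number 34 percentage points higher from compound 1 to compound 2 (beyond the scatter) and a number 58 percentage points lower from compound 2 to compound 3 (beyond the scatter), while a number 24 percentage points lower from compound 1 to compound 3 (beyond the scatter) is smaller; the fact that one of compounds 1 and 3 is drawn with a defined configuration and the other without, at the place where they differ is the only difference in that pair. Compound 4 `COc1ccccc1-n1nc(C2=CC(C)(C)OC(C)(C)C2)cc1-c1ccc(Cl)cc1` carries the change (a group of 10 heavy atoms (9 carbon, 1 oxygen; one six-membered non-aromatic ring with 1 hetero atom) in place of a group of 8 heavy atoms (7 carbon, 1 oxygen; one six-membered non-aromatic ring with 1 hetero atom), on an aromatic carbon). Going by the values given here, no measured step shows this exact group, so the step from compound 1 to compound 2 is the nearest guide. A smaller rise is expected, estimated as a number 12 percentage points higher from compound 1 to compound 4 (beyond the scatter). Compound 4 is therefore estimated at 76% in this assay, within 48% to 97%.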

Compound 4, percent of the compound remaining: 96%
Compound 4: middle estimate off by 20 percentage points, on the low side; low and high end bracket the measured number.
By their numbers in this assay, from the lowest: compound 3; then compound 1; then compounds 4 and 2 (each within the scatter of the next).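

At this aromatic carbon, the group of 10 heavy atoms with its double bond outside aromatic rings gives a number 32 percentage points higher from compound 1 to compound 4 (beyond the scatter) and a number 56 percentage points higher from compound 3 to compound 4 (beyond the scatter). With a number 2 percentage points lower from compound 2 to compound 4 (within the scatter), high numbers in this assay are not confined to the 2,2-dimethyloxan-4-yl group. Nothing available accounts for this result.

The compounds shown do not separate the contribution of the double bond from that of the two additional carbon atoms. From the compounds shown here alone, how an amine or a carboxylic acid on this ring would read out remains open.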